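Notes on compound 1 and its pyridin-3-yl analogue

The source may hold more compounds than are shown below. What is called first, only, known or untested is meant among the compounds shown, and "the series" means these compounds.

Measured in a functional assay on HeLa cells (Homo sapiens) for cytotoxicity, read by sulforhodamine B assay, with a stated time of 48 h; on this read-out higher numbers stand for weaker inhibition and lower numbers for stronger inhibition:
- compound 1 `CC1=C(/C=C/C(=O)/C=C/c2ccccc2)C(C)(C)CCC1`: 70200 nM
- compound 2 `COc1ccc(/C=C/C(=O)/C=C/C2=C(C)CCCC2(C)C)cc1OC`: 85000 nM

Only these two numbers exist in this assay, and they sit within the usual scatter of each other, so compound 1 and compound 2 cannot be ranked against one another on this evidence. Going by the values given here, no pair of measured compounds differs in one place, so nothing measured shows the size of any single structural step in this set.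

Compound 3 `CC1=C(/C=C/C(=O)/C=C/c2cccnc2)C(C)(C)CCC1` is not yet measured. Relative to compound 1 it carries pyridin-3-yl in place of phenyl on a double-bonded chain carbon bound to a double-bonded chain carbon. Among the compounds with values here, no measured pair carries this exchange, so there is no precedent for its effect. The expectation is therefore a step of a 1.0-fold lower number from compound 1 to compound 3 (0.00 log units; within the scatter), which is taken as none beyond the scatter, in no preferred direction. On that basis compound 3 is estimated at 70000 nM in this assay, with a range from 25000 nM to 200000 nM.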

Compound 3, half-maximal inhibitory concentration: 17400 nM
Compound 3: the middle estimate sits 4.0-fold (0.60 log units) above what was measured; the measured number lies below the stated range.
By their numbers in this assay, from the lowest: compound 3; then compounds 1 and 2 (each within the scatter of the next).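

In this assay, going by these compounds alone, pyridin-3-yl in place of phenyl on a double-bonded chain carbon bound to a double-bonded chain carbon gives a 4.0-fold lower number from compound 1 to compound 3 (0.61 log units; beyond the scatter), the first single-place step. This position therefore responds to the identity of the ring it carries: with the core of compound 1 held constant, entry of a ring nitrogen, counted as one hydrogen-bond acceptor, goes with stronger inhibition, although the step is modest. No evidence available here accounts for the step.

On these data alone, it remains open whether the ring nitrogen itself is what matters, or whether a pyrimidine or thiophene ring at the same place would give a similar, larger or smaller step. Also open, as far as these compounds go, is whether a phenyl ring bearing a dimethylamino group or a carboxylic acid would move the number in either direction.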